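Shortening an ethylamino chain on a quinazoline-type amine series

The source may report more compounds than this note shows. Statements on the series, on what has been measured and on what is new or still open speak of the compounds shown alone.

Compound 1 `CCNc1nc(NCc2ccc(NC(=O)c3ccc(F)cc3)cc2)c2ccccc2n1`: 1400 nM
Compound 2 `CCCNc1nc(NCc2ccc(C(=O)N3CCC(C(=O)NCc4ccc(F)cc4)CC3)cc2)c2cc(C)ccc2n1`: 4600 nM
Compound 3 `CCNc1nc(NCc2ccc(NC(=O)c3ccc(F)cc3)cc2Cl)c2ccccc2n1`: 1500 nM

In a functional assay on HCT-116 cells (Homo sapiens) for inhibition, read by luminescence and resazurin assay, with a stated time of 3 days (on this read-out lower numbers stand for stronger inhibition and higher numbers for weaker inhibition), compound 1 and compound 3 lie within the scatter of each other, while compound 2 gives a higher number, beyond the scatter. Compound 4 `CNc1nc(NCc2ccc(NC(=O)c3ccc(F)cc3)cc2)c2ccccc2n1` differs from compound 1 by hydrogen in place of methyl on a saturated chain carbon bound to a nitrogen on an aromatic ring. Going by the values given here, the only step measured in one place, a 1.1-fold higher number from compound 1 to compound 3 (0.03 log units; within the scatter), concerns a different change and says nothing directly about this one. Among the compounds with values here, no measured step bears on the ethylamino to methylamino change, so no step beyond the scatter is expected in this assay. The expected step is a 1.3-fold higher number from compound 1 to compound 4 (0.11 log units; within the scatter). Compound 4 is therefore estimated to give 1800 nM, with a range from 700 nM to 4500 nM.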

Compound 4, half-maximal inhibitory concentration: 1600 nM
For compound 4 the middle estimate is 1.1-fold (0.05 log units) above the measured one; measured number inside the range.
By their numbers in this assay, from the lowest: compounds 1, 3 and 4 (each within the scatter of the next); then compound 2.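

In this assay, going by these compounds alone, the ethylamino to methylamino change gives the only step read on this chain, since the chloro step lies elsewhere on the molecule. With a 1.1-fold higher number from compound 1 to compound 4 (0.06 log units; within the scatter), the chain can lose this methyl without a step beyond the scatter. Nothing shown here offers an explanation for this result.

On these data alone, whether a butyl chain or a plain amine at this place would also stay within the scatter remains open. Compound 2 carries a propylamino chain but differs in other places too, so it cannot settle this.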